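Inverting the chain stereocentre in the chloro analogue

A few compounds are considered here, and "the series" means these few. Any claim that something is new, unique, unknown or untested is made for them only; others in the source may bear on it.

Within the data shown here, compound 3 `Cc1ccc(NC(=O)c2ccc(Cl)c(C(F)(F)F)c2)cc1C#Cc1nn(C[C@@H](C)CO)c2ncnc(N)c12` gives 23 nM in a functional assay on MDA-MB-231 cells (Homo sapiens) for antiproliferative activity, read by MTT assay, with a stated time of 72 h (a lower number here means a stronger inhibitor, a higher number a weaker inhibitor), the second highest of the three numbers so far; it sits nearest to compound 2 `Cc1ccc(NC(=O)c2ccc(C)c(C(F)(F)F)c2)cc1C#Cc1nn(C[C@H](C)CO)c2ncnc(N)c12`, which gives 43 nM (within the scatter), and furthest from compound 1 `Cc1ccc(NC(=O)c2cccc(C(F)(F)F)c2)cc1C#Cc1nn(C[C@H](C)CO)c2ncnc(N)c12`, which gives 10 nM. Compound 4 `Cc1ccc(NC(=O)c2ccc(Cl)c(C(F)(F)F)c2)cc1C#Cc1nn(C[C@H](C)CO)c2ncnc(N)c12` differs from compound 3 only in this: the two compounds have the same atoms and bonds and differ only in configuration as drawn: 1 of 1 stereo elements differ; a stereocentre at a saturated chain carbon is drawn R in compound 3 and S in compound 4. Among the measured compounds shown here, none of the measured steps touches this stereocentre; the only step, a 4.3-fold higher number from compound 1 to compound 2 (0.63 log units; beyond the scatter), concerns a methyl in place of hydrogen on an aromatic carbon and so says nothing about configuration. Compounds 1 and 2 both carry the configuration drawn in compound 4 and span the whole range of numbers seen, so that configuration is compatible with both the lowest and the highest values. With no direct evidence, compound 4 is expected to stay close to compound 3, with the step of a 1.3-fold lower number from compound 3 to compound 4 (0.11 log units; within the scatter) estimated not to exceed the scatter. Compound 4 is therefore estimated at 18 nM, within 6 nM to 60 nM.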

Compound 4, half-maximal inhibitory concentration: 17 nM
The estimate for compound 4 lay 1.1-fold (0.02 log units) above the measured number; low and high end bracket the measured number.
By their numbers in this assay, from the lowest: compounds 1, 4, 3 and 2 (each within the scatter of the next, the first and the last beyond it).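

In this assay, the only direct test of the chain stereocentre, a 1.4-fold lower number from compound 3 to compound 4 (0.13 log units; within the scatter), stays within the scatter, and this comparison isolates configuration alone: the fact that compounds 3 and 4 differ only in the configuration as drawn At the aromatic carbon that varies, chloro in place of methyl gives a 2.5-fold lower number from compound 2 to compound 4 (0.40 log units; beyond the scatter), which lies beyond the scatter, while chloro in place of hydrogen gives a 1.7-fold higher number from compound 1 to compound 4 (0.23 log units; within the scatter), which stays within it. Among these compounds, then, chloro at this carbon cannot be told apart from hydrogen, whereas methyl can be told apart from both.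

The compounds shown leave open whether configuration is equally unimportant when this aromatic carbon carries hydrogen or methyl rather than chloro. They also leave open how a methoxy group at this carbon, or an amine in place of the hydroxyl at the end of the chain, would fare.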